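Amide side chain variation on a shared core

The source may hold more compounds than are shown below. What is called first, only, known or untested is meant among the compounds shown, and "the series" means these compounds.

Compound 2, `CCn1c(C(=O)NCCCN(C)C)ccc1C(CC)(CC)c1ccc(OCC(O)C(C)(C)C)c(C)c1`, gives 1900 nM in a functional assay on Caco-2 cells (Homo sapiens), read by MTT assay, with a stated time of 48 h (a lower number here means a stronger inhibitor, a higher number a weaker inhibitor), the lowest of the two numbers recorded. Compound 1, `CCOC(=O)CN(C)C(=O)c1ccc(C(CC)(CC)c2ccc(OCC(O)C(C)(C)C)c(C)c2)n1CC`, gives 12200 nM in this assay; the step of a 6.4-fold lower number from compound 1 to compound 2 (0.81 log units; beyond the scatter) is beyond the scatter. Compound 3, `CCn1c(C(=O)N(C)CCC#N)ccc1C(CC)(CC)c1ccc(OCC(O)C(C)(C)C)c(C)c1`, reaches only the limit > 50000 nM in this assay, so its number is not known (the limit of > 50000 nM in this assay, at which 1 of the 3 values shown sits). The step of an at least 26-fold higher number from compound 2 to compound 3 (1.42 log units; beyond the scatter) shows that exchanging the amide substituent can move the number far.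

Compound 4, `CC[C@@H](C)[C@H](NC(=O)c1ccc(C(CC)(CC)c2ccc(OCC(O)C(C)(C)C)c(C)c2)n1CC)C(=O)O`, differs from compound 2 only at the amide: 1-carboxy-2-methylbutyl in place of 3-(dimethylamino)propyl on an amide-type nitrogen. Neither measured step covers a carboxylic acid on this nitrogen, yet both show that the amide substituent matters, with the basic chain of compound 2 standing lowest. Compound 4 is therefore expected to give a higher number than compound 2, estimated as 15000 nM, with a range from 3000 nM to 50000 nM. The step expected from this estimate is a 7.9-fold higher number from compound 2 to compound 4 (0.90 log units; beyond the scatter).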

Compound 4, half-maximal inhibitory concentration: 3400 nM
Compound 4: middle estimate off by 4.4-fold (0.64 log units), on the high side; low and high end bracket the measured number.
By their numbers in this assay, from the lowest: compounds 2 and 4 (each within the scatter of the next); then compound 1. At a limit, above all of these: compound 3.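

With the 1-carboxy-2-methylbutyl chain on the amide-type nitrogen, this assay gives a 1.8-fold higher number from compound 2 to compound 4 (0.25 log units; within the scatter), so the 3-(dimethylamino)propyl chain is not the only substituent shown that reaches this range. The same chain also stands apart from the other two amides, with a 3.6-fold lower number from compound 1 to compound 4 (0.55 log units; beyond the scatter) and an at least 14-fold lower number from compound 3 to compound 4 (1.16 log units; beyond the scatter). The value of compound 3 in that last step is only a limit: the limit of > 50000 nM in this assay, at which 1 of the 4 values shown sits.

The compounds shown leave open whether the carboxylic acid or the branched alkyl part of this chain carries the result, since an ethyl ester of compound 4 or a plain 2-methylbutyl chain would separate the two. They also leave open how the two defined stereocentres of compound 4 bear on the number, which the opposite stereoisomers would test.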